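A few compounds are considered here, and "the series" means these few. Any claim that something is new, unique, unknown or untested is made for them only; others in the source may bear on it.

Working notes on the hydantoin-type series and the step from compound 3 to compound 4.

Compound 3 `O=C1N/C(=C\c2ccc(O)cc2)C(=O)N1c1ccc(Br)cc1` gives 69900 nM in a functional assay on NCI-H292 cells (Homo sapiens) for antiproliferative activity (a higher number here means a weaker inhibitor, a lower number a stronger inhibitor), the higher of the two numbers obtained so far. Compound 1 `O=C1N/C(=C\c2ccc(O)cc2)C(=O)N1c1ccc(I)cc1` gives 25500 nM in this assay; the step of a 2.7-fold higher number from compound 1 to compound 3 (0.44 log units; beyond the scatter) is the only measured one with a single change, and it swaps one halogen for another on the same phenyl ring. Compound 2 `COc1cccc(N2C(=O)N/C(=C\c3ccc(O)cc3)C2=O)c1` gives > 200000 nM, which is a limit of the assay and not a number, as stated in the limit of > 200000 nM in this assay, at which 1 of the 3 values shown sits. Among the compounds with values here, compound 2 therefore sets no scale for any step.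

Compound 4 `O=C1N/C(=C\c2ccc(O)cc2)C(=O)N1c1cccc(Br)c1` is the next member; it differs from compound 3 by 3-bromophenyl in place of 4-bromophenyl on an amide-type nitrogen in a ring. Within the data shown here, no measured step moves the bromine around its ring, so the step from compound 3 to compound 4 has no direct precedent; the halogen swap from compound 1 to compound 3 was modest, and a repositioning of the same bromine is expected to stay within a similarly modest span, in either direction. The estimate for compound 4 is 100000 nM in this assay, with a range from 30000 nM to 300000 nM, implying an expected step of a 1.4-fold higher number from compound 3 to compound 4 (0.16 log units; within the scatter), with a fair chance that only a limit is returned. The measurement for compound 4 follows.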

Compound 4, half-maximal inhibitory concentration: > 200000 nM
Compound 4 ended at the assay's limit; the forecaster's own chance of this, stated with the estimate: 25%; at least 2.0-fold (0.30 log units) between middle value and limit.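

Moving the bromine on the phenyl ring carried by the ring nitrogen is not a neutral change in this assay: with the same atoms joined differently, the series shows an at least 2.8-fold higher number from compound 3 to compound 4 (0.45 log units; beyond the scatter), so the place of the halogen matters as well as its identity, which the halogen swap alone could not show. The change of both halogen and place gives an at least 7.8-fold higher number from compound 1 to compound 4 (0.89 log units; beyond the scatter), and among the compounds shown, readable numbers remain only for compound 1, with 4-iodophenyl, and compound 3, with 4-bromophenyl. Compound 2 and compound 4 both stand at a limit of the assay rather than at a number, and the step between them cannot be read: the limit of > 200000 nM in this assay, at which 2 of the 4 values shown sit.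

On these data alone, how far compound 4 lies beyond its limit remains open, so the full size of the effect of moving the bromine is unknown. Also open, as far as these compounds go, is whether an amine or a carboxylic acid on this phenyl ring, in place of the halogen, would return a readable number in this assay.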